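Moving the fluoro on the indole of compound 1

The source may hold more compounds than are shown below. What is called first, only, known or untested is meant among the compounds shown, and "the series" means these compounds.

Measured so far in a functional assay on SW480 cells (Homo sapiens) for antiproliferative activity, with a stated time of 72 h; a higher number here means a weaker inhibitor, a lower number a stronger inhibitor:
compound 1 `O=C(COc1ccc(CN2CC=C(c3c[nH]c4cccc(F)c34)CC2)c(F)c1)NO`: 5560 nM
compound 2 `O=C(COc1ccc(CN2CC=C(c3c[nH]c4cccc(F)c34)CC2)cc1)NO`: 2310 nM

Compound 1 stands at the higher of the two numbers, so it is the weaker inhibitor of this pair, and compound 2 is its nearest neighbour.

Compound 3 `O=C(COc1ccc(CN2CC=C(c3c[nH]c4ccc(F)cc34)CC2)c(F)c1)NO` has not yet been measured. It differs from compound 1 in one place: 5-fluoro-1H-indol-3-yl in place of 4-fluoro-1H-indol-3-yl on a double-bonded ring carbon. In words, 5-fluoro-1H-indol-3-yl replaces 4-fluoro-1H-indol-3-yl on a double-bonded ring carbon, so the two have the same atoms, joined differently.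

Within the data shown here, no measured step shifts the fluoro on this group. Among the measured compounds shown here, compound 2 keeps the 4-fluoro-1H-indol-3-yl group, and the only measured step, a 2.4-fold lower number from compound 1 to compound 2 (0.38 log units; beyond the scatter), concerns a different fluoro, so it serves only as a rough guide to size. On that modest step, no change beyond the scatter is expected in this assay, and the data favour no direction. The estimated step is a 1.2-fold lower number from compound 1 to compound 3 (0.09 log units; within the scatter). Compound 3 is expected at 4500 nM, with an estimated range from 1900 nM to 10500 nM.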

Compound 3, half-maximal inhibitory concentration: 3860 nM
Estimate against measurement, compound 3: 1.2-fold (0.07 log units) above; the measured number falls inside the stated range.
By their numbers in this assay, from the lowest: compounds 2, 3 and 1 (each within the scatter of the next, the first and the last beyond it).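

In this assay, among these compounds, the shift of the fluoro within this group gives a 1.4-fold lower number from compound 1 to compound 3 (0.16 log units; within the scatter), and this is the first reading of any change at the group on the double-bonded ring carbon. Among the compounds shown here, the only earlier step, a 2.4-fold lower number from compound 1 to compound 2 (0.38 log units; beyond the scatter), concerned a different fluoro and lay beyond the scatter, whereas exchanging 4-fluoro-1H-indol-3-yl for 5-fluoro-1H-indol-3-yl, two groups with the same atoms joined differently, stays within it. So, for this one pair and this one read-out, the place of the fluoro on this group does not separate the two compounds, and nothing presented here gives a reason for that result.

These compounds leave open whether the same holds without the other fluoro, as the 5-fluoro-1H-indol-3-yl group appears only in compound 3 and no compound pairs it with the hydrogen found in compound 2. They also leave open what the fluoro itself contributes, since neither plain 1H-indol-3-yl nor a chloro or methoxy group in its place is among them, so only the two fluoro placements can be compared.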